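The source may report more compounds than this note shows. Statements on the series, on what has been measured and on what is new or still open speak of the compounds shown alone.

Three compounds built on a shared core are compared in a functional assay on ECa-109 cells for inhibition, with ECa-109 cell line (Homo sapiens) as the target, read by sulforhodamine B assay; a lower number here means a stronger inhibitor, a higher number a weaker inhibitor. Compound 1 `O=C1C=C(N2CCC2)C(=O)c2c1nc1n2[C@H]2OC[C@@H](O)[C@H]2OC1` gives > 16000 nM, which is a limit of the assay and not a true number. Going by the values given here, compound 2 `CCOc1ccccc1NC1=CC(=O)c2nc3n(c2C1=O)[C@H]1OC[C@@H](O)[C@H]1OC3` gives 4630 nM, the only actual number available so far. Compound 3 `O=C1C=C(Nc2ccccc2)C(=O)c2c1nc1n2[C@H]2OC[C@@H](O)[C@H]2OC1` has not yet been measured. It differs from compound 2 in one place: hydrogen in place of ethoxy on an aromatic carbon. Hydrogen stands in place of ethoxy on an aromatic carbon, so 2-ethoxyphenyl becomes phenyl. Among the compounds with values here, no measured pair shows what this change does, so the expectation stays close to compound 2 at 4630 nM in this assay. No step beyond the scatter is expected, with a slight lean toward a weaker inhibitor. The estimated change is a 1.3-fold higher number from compound 2 to compound 3 (0.11 log units; within the scatter). For compound 3 the expected value is 6000 nM, with an estimated range from 2000 nM to 15000 nM.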

Compound 3, half-maximal inhibitory concentration: 4970 nM
The estimate for compound 3 lay 1.2-fold (0.08 log units) above the measured number; the measured number falls inside the stated range.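

In this assay, hydrogen in place of ethoxy on the aromatic ring gives a 1.1-fold higher number from compound 2 to compound 3 (0.03 log units; within the scatter), so the 2-ethoxyphenyl and phenyl compounds cannot be told apart here, and ethoxy is not needed for the potency of compound 2. Anilino in place of azetidin-1-yl gives an at least 3.2-fold lower number from compound 1 to compound 3 (0.50 log units; beyond the scatter), which shows that the anilino group without any ethoxy already stands apart from azetidin-1-yl. Compound 1 sits at a limit of the assay and not at a true number, so this step gives only a minimum size: the limit of > 16000 nM in this assay, at which 1 of the 3 values shown sits.

Still open, on these data alone, is whether a different group at this place on the ring, such as a carboxylic acid or a dimethylamino group, would move the number beyond the scatter. As far as these compounds go, how far the number could fall remains open too, as the two ring-bearing compounds alone cannot show it.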